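A few compounds are considered here, and "the series" means these few. Any claim that something is new, unique, unknown or untested is made for them only; others in the source may bear on it.

Compound 1 `COc1cc(-n2cnc3ccc(-c4cc(F)ccc4F)cc32)cc(OC)c1OC`: 6590 nM
Compound 2 `COc1cc(-n2cnc3ccc(-c4ccc([N+](=O)[O-])cc4)cc32)cc(OC)c1OC`: 79 nM
Compound 3 `COc1cc(-n2cnc3ccc(-c4cccc(O)c4)cc32)cc(OC)c1OC`: 53 nM

All three values come from a functional assay on SGC-7901 cells (Homo sapiens) for antiproliferative activity, read by MTT assay, with a stated time of 72 h; on this read-out higher numbers stand for weaker inhibition and lower numbers for stronger inhibition. Compound 3 sits within the scatter of compound 2 and far from compound 1. Compound 4 `COc1cc(-n2cnc3ccc(-c4ccc(C)cc4)cc32)cc(OC)c1OC` keeps the shared core and differs from compound 3 as follows: 4-methylphenyl in place of 3-hydroxyphenyl on an aromatic carbon. For the measured compounds named here, three measured steps concern this same aromatic carbon. The step of a 1.5-fold lower number from compound 2 to compound 3 (0.17 log units; within the scatter) stays within the scatter, whereas an 83-fold lower number from compound 1 to compound 2 (1.92 log units; beyond the scatter) and a 120-fold lower number from compound 1 to compound 3 (2.09 log units; beyond the scatter) are both large. Going by the values given here, a change here can therefore matter little or greatly, and no measured compound carries the 4-methylphenyl group. A moderate rise in this assay is expected, though it may not exceed the scatter. The estimated step is a 3.2-fold higher number from compound 3 to compound 4 (0.51 log units; beyond the scatter). For compound 4 the expected value is 170 nM, within an estimated range of 35 nM to 1500 nM.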

Compound 4, half-maximal inhibitory concentration: 200 nM
Beside the measured number, compound 4's estimate is 1.2-fold (0.07 log units) below it; the measured number falls inside the stated range.
By their numbers in this assay, from the lowest: compounds 3 and 2 (each within the scatter of the next); then compound 4; then compound 1.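

Replacing 3-hydroxyphenyl with 4-methylphenyl gives a modest change at this aromatic carbon in this assay, a 3.8-fold higher number from compound 3 to compound 4 (0.58 log units; beyond the scatter), so steps here are not only small or large. Methyl in place of nitro also separates two groups that looked alike in their strength of effect, with a 2.5-fold higher number from compound 2 to compound 4 (0.40 log units; beyond the scatter). A hydrogen-bond donor or acceptor in this group is not required for most of the gain over 2,5-difluorophenyl, as shown by a 33-fold lower number from compound 1 to compound 4 (1.52 log units; beyond the scatter).

From the compounds shown here alone, how an amine or a carboxylic acid would behave on this phenyl ring remains open. Nothing given here explains these steps.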